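The source may report more compounds than this note shows. Statements on the series, on what has been measured and on what is new or still open speak of the compounds shown alone.

Compound 1 `Cc1cccc(-n2nncc2CN2C(=O)C3(C(C#N)=C(N)Oc4c3c3nc5ccccc5nc3c3ccccc43)c3ccccc32)c1`: > 50000 nM
Compound 2 `CCc1ccccc1-n1nncc1CN1C(=O)C2(C(C#N)=C(N)Oc3c(N)cc4nc5ccccc5nc4c32)c2ccccc21`: 17900 nM
Compound 3 `N#CC1=C(N)Oc2c(N)cc3nc4ccccc4nc3c2C12C(=O)N(Cc1cnnn1-c1ccc(F)cc1)c1ccccc12`: > 50000 nM

In a functional assay on HepG2 cells (Homo sapiens) for antiproliferative activity, read by MTT assay, with a stated time of 48 h (on this read-out higher numbers stand for weaker inhibition and lower numbers for stronger inhibition), compound 3 gives only a limit, > 50000 nM, and no number. Compound 1 likewise stops at a limit, > 50000 nM. Within the data shown here, compound 2 is the only compound with a number, 17900 nM. Compound 3 thus sits at the ceiling of the assay, (the limit of > 50000 nM in this assay, at which 2 of the 3 values shown sit). Compound 4 `N#CC1=C(N)Oc2c(N)cc3nc4ccccc4nc3c2C12C(=O)N(Cc1cnnn1-c1ccccc1Br)c1ccccc12` differs from compound 3 by 2-bromophenyl in place of 4-fluorophenyl on an aromatic nitrogen. Among the measured compounds shown here, the one measured step that touches this position is an at least 2.7-fold higher number from compound 2 to compound 3 (0.44 log units; beyond the scatter), in which 2-ethylphenyl gave way to 4-fluorophenyl and the number rose out of range. Compound 4 carries a 2-bromophenyl, which, like the 2-ethylphenyl of compound 2, differs from the 4-fluorophenyl of compound 3. On that basis a return toward the number of compound 2 is expected for compound 4, namely an at least 1.6-fold lower number from compound 3 to compound 4 (0.22 log units; that floor lies within the scatter). Compound 4 is therefore estimated at 30000 nM, with a range from 12000 nM to 80000 nM, and with a fair chance that this assay again reports only a limit.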

Compound 4, half-maximal inhibitory concentration: 38000 nM
Compound 4: middle estimate off by 1.3-fold (0.10 log units), on the low side, and the stated range covers the measured number.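

In this assay, 2-bromophenyl in place of 4-fluorophenyl gives an at least 1.3-fold lower number from compound 3 to compound 4 (0.11 log units; that floor lies within the scatter), so this position can return a number where the fluorinated compound did not, but the true size of the step cannot be read. Compound 3 gives only a limit: the limit of > 50000 nM in this assay, at which 2 of the 4 values shown sit. Within the 2-substituted phenyls, bromo in place of ethyl gives a 2.1-fold higher number from compound 2 to compound 4 (0.33 log units; beyond the scatter), so at this position the group on the phenyl ring changes the number modestly, and the 2-ethylphenyl of compound 2 keeps the lower value.

From the compounds shown here alone, whether the number follows the halogen or its place on the phenyl stays open, as compound 3 and compound 4 differ in both. Going by these compounds, how an amine or a carboxylic acid in place of the bromo would read is also open.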